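Aryl exchange at the exocyclic double bond: compound 4

The source may report more compounds than this note shows. Statements on the series, on what has been measured and on what is new or still open speak of the compounds shown alone.

For the measured compounds named here, the three measured members share one core and differ only in the aryl group on a double-bonded chain carbon bound to a double-bonded ring carbon. In a functional assay on HepG2 cells (Homo sapiens) for antiproliferative activity, read by MTT assay (a lower number here means a stronger inhibitor, a higher number a weaker inhibitor), compound 1 `O=C1N=C(N2CCC[C@H]2C(=O)Nc2ccc3ncnc(Nc4cccc(Cl)c4)c3c2)S/C1=C/c1cccc(Cl)c1` gives 27600 nM, compound 2 `Cc1cccc(/C=C2/SC(N3CCC[C@H]3C(=O)Nc3ccc4ncnc(Nc5cccc(Cl)c5)c4c3)=NC2=O)n1` gives 4500 nM, and compound 3 `O=C1N=C(N2CCC[C@H]2C(=O)Nc2ccc3ncnc(Nc4cccc(Cl)c4)c3c2)S/C1=C/c1ccc(-c2ccccc2)cc1` gives 15400 nM. Compound 3 thus holds the second highest of the three numbers; its gap to compound 1 is within the scatter, whereas compound 2 sits clearly lower, as a 3.4-fold higher number from compound 2 to compound 3 (0.53 log units; beyond the scatter) shows.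

Compound 4 `O=C1N=C(N2CCC[C@H]2C(=O)Nc2ccc3ncnc(Nc4cccc(Cl)c4)c3c2)S/C1=C/c1cccs1` continues the same exchange: thiophen-2-yl in place of 4-phenylphenyl on a double-bonded chain carbon bound to a double-bonded ring carbon. All three measured steps bear on it, since each swaps this aryl group: a 6.1-fold lower number from compound 1 to compound 2 (0.79 log units; beyond the scatter), a 1.8-fold lower number from compound 1 to compound 3 (0.25 log units; within the scatter) and a 3.4-fold higher number from compound 2 to compound 3 (0.53 log units; beyond the scatter). None of them exceeds a modest size, and the one case where a heteroaryl entered, compound 2 with 4500 nM, gave the lowest number of the set. A modest step toward a lower number is therefore expected in this assay, with a real possibility that it stays within the scatter.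

The expected step for compound 4 is a 1.7-fold lower number from compound 3 to compound 4 (0.23 log units; within the scatter). Compound 4 is estimated at 9000 nM, with a range from 3000 nM to 27000 nM.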

Compound 4, half-maximal inhibitory concentration: 4120 nM
Estimate against measurement, compound 4: 2.2-fold (0.34 log units) above, and the stated range covers the measured number.
By their numbers in this assay, from the lowest: compounds 4 and 2 (each within the scatter of the next); then compounds 3 and 1 (each within the scatter of the next).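

In this assay, thiophen-2-yl in place of 4-phenylphenyl gives a 3.7-fold lower number from compound 3 to compound 4 (0.57 log units; beyond the scatter), and the same group in place of 3-chlorophenyl gives a 6.7-fold lower number from compound 1 to compound 4 (0.83 log units; beyond the scatter), so a second aryl group with a ring hetero atom now separates from both aryl groups whose rings are carbon only. With a 1.1-fold lower number from compound 2 to compound 4 (0.04 log units; within the scatter), the five-membered sulfur ring and the 6-methylpyridin-2-yl group cannot be told apart at this position, and among these four compounds the split follows the presence of a ring hetero atom, with none going against it, where earlier it rested on compound 2 alone. No measurement at hand offers an explanation for this split.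

Four aryl groups cannot separate the hetero atom from ring size or from the substituents carried by each ring, since compound 4 also has far fewer heavy atoms than compound 3 and lacks the chlorine of compound 1. Going by these compounds, it remains open whether furan-2-yl, unsubstituted pyridin-2-yl or a thiophen-2-yl ring bearing a carboxylic acid or an amine would stay with compounds 2 and 4 in this assay.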